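The compounds below may be only part of what the source reports. "The series", "measured", "known", "first", "only" and "open" are said of these compounds alone.

Measured so far:
Compound 1, `O=C(O)C1CCN(c2ccccc2)C1`: 48000 nM
Compound 2, `O=C(O)C1CCN(c2ccccc2F)C1`: 11000 nM
Compound 3, `O=C(O)C1CCN(c2ccccc2Cl)C1`: 19000 nM

Compound 1 is the unsubstituted member of this small set, and in an assay on cells for inhibition of Palmitoleoyl-protein carboxylesterase NOTUM variant C330S (Homo sapiens), read by fluorescence, with a stated time of 40 min (on this read-out lower numbers stand for stronger inhibition and higher numbers for weaker inhibition), it gives the highest number of the three, so it is the weakest inhibitor among them. The two measured steps that start from it both put a halogen onto the phenyl ring: a 4.4-fold lower number from compound 1 to compound 2 (0.64 log units; beyond the scatter) and a 2.5-fold lower number from compound 1 to compound 3 (0.40 log units; beyond the scatter), both beyond the scatter but modest in size. Between the two halogenated compounds the gap is a 1.7-fold higher number from compound 2 to compound 3 (0.24 log units; within the scatter), which stays within the scatter.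

Compound 4, `Cc1cccc(N2CCC(C(=O)O)C2)c1`, is the next compound to be measured. It differs from compound 1 in one place: methyl in place of hydrogen on an aromatic carbon. For the measured compounds named here, no measured step puts a methyl on this ring, and the halogen steps sit at a different position, so their bearing is only indirect: they show that a single small substituent on the phenyl ring can lower the number in this assay by a modest amount. By analogy a small move in the same direction is expected for compound 4, though one that may not clear the scatter.

Compound 4 is therefore estimated to give about 30000 nM in this assay, within a range from 12000 nM to 70000 nM. This estimate means a step of a 1.6-fold lower number from compound 1 to compound 4 (0.20 log units; within the scatter) from compound 1.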

Compound 4, half-maximal inhibitory concentration: 49000 nM
The estimate for compound 4 lay 1.6-fold (0.21 log units) below the measured number; measured number inside the range.
By their numbers in this assay, from the lowest: compounds 2 and 3 (each within the scatter of the next); then compounds 1 and 4 (each within the scatter of the next).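

In this assay, a methyl on an aromatic carbon, meta to a group of 8 heavy atoms, gives a 1.0-fold higher number from compound 1 to compound 4 (0.01 log units; within the scatter) and so leaves compound 4 indistinguishable from compound 1 within the usual scatter. This shows that a single small substituent on the aromatic ring is not enough to lower the number, as the halogen steps alone might have suggested: a 4.4-fold lower number from compound 1 to compound 2 (0.64 log units; beyond the scatter) and a 2.5-fold lower number from compound 1 to compound 3 (0.40 log units; beyond the scatter) both lie beyond the scatter, whereas the methyl step does not. Because the methyl differs from those halogens in both its identity and its place on the ring, and no measurement here explains the contrast, the result cannot be assigned to either difference.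

The compounds shown leave open whether a fluoro or chloro at the methyl's position would lower the number, and whether a methyl at the position held by the halogens in compound 2 and compound 3 would do so. They also leave open how larger or different groups at the methyl's position, such as an amine, a methoxy group or a longer chain, would read in this assay.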